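The source may hold more compounds than are shown below. What is called first, only, known or untested is meant among the compounds shown, and "the series" means these compounds.

Measured so far in an ADME assay on SH-SY5Y cells (Homo sapiens) for cytotoxicity, read by MTT assay, with a stated time of 72 h; on this read-out higher numbers stand for weaker inhibition and lower numbers for stronger inhibition:

compound 1, `O=C(CN1CCN(C(=O)c2ccccc2)CC1)N1CCN(CCCc2c[nH]c3ccccc23)CC1`: > 200000 nM
compound 2, `O=C(CN1CCN(C(=O)c2ccc(F)cc2)CC1)N1CCN(CCCc2c[nH]c3ccccc23)CC1`: 188000 nM

Compound 1 stands only at a limit of this assay; its entry > 200000 nM is a limit and not a number, so it marks the weakest inhibition the assay reports (the limit of > 200000 nM in this assay, at which 1 of the 2 values shown sits). For compound 2 the read-out is a number, 188000 nM, and the step of an at least 1.0-fold lower number from compound 1 to compound 2 (0.02 log units; that floor lies within the scatter) lies within the scatter, so the two compounds are not told apart.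

Compound 3 is `O=C(CN1CCN(C(=O)c2cccc(Br)c2)CC1)N1CCN(CCCc2c[nH]c3ccccc23)CC1`. Against compound 1 the difference is bromo in place of hydrogen on an aromatic carbon. Among the measured compounds shown here, the only measured step that bears on this change is an at least 1.0-fold lower number from compound 1 to compound 2 (0.02 log units; that floor lies within the scatter), which likewise trades a hydrogen for a halogen and moves the number by no more than the scatter allows. On that basis no step beyond the scatter is expected for compound 3 in this assay; the expected step is a number no higher from compound 1 to compound 3 (the limit leaves the size open). Compound 3 is therefore estimated at 200000 nM, with a range of 120000 nM to 320000 nM, and a fair chance that the assay again reports only its limit.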

Compound 3, half-maximal inhibitory concentration: 80500 nM
Compound 3: the middle estimate sits 2.5-fold (0.40 log units) above what was measured; the whole stated range lies above it.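

In this assay, bromo in place of hydrogen on an aromatic carbon, meta to a large group, gives a step beyond the scatter, which the fluoro change did not: an at least 2.4-fold lower number from compound 1 to compound 3 (0.39 log units; beyond the scatter). The change from 4-fluorophenyl to 3-bromophenyl on the carbonyl carbon gives a 2.3-fold lower number from compound 2 to compound 3 (0.37 log units; beyond the scatter), so compound 3 stands apart from both earlier compounds, and trading a hydrogen for a halogen on this ring does not act alike in the two cases. Compound 1 gives > 200000 nM, which is a limit and not a number, so the step from it has a floor and no measured size: the limit of > 200000 nM in this assay, at which 1 of the 3 values shown sits.

Compound 2 and compound 3 differ in both the halogen and its place on the ring, so the compounds shown do not separate the effect of bromo from the effect of where it sits. On these data alone, it also stays open whether the lower number belongs to bromo alone or would also come with another group on the same carbon, such as chloro, methyl or methoxy.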